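This account rests on a few compounds, and the source may have more. Where it says the series, first, only, none or still open, it means among the compounds named here.

Measured so far:
compound 1, `NC(=S)N/N=C/c1ccc2ccccc2n1`: 960 nM
compound 2, `Cc1ccc(NC(=O)N/N=C/c2ccc3ccccc3n2)cc1`: > 100000 nM
compound 3, `CC(C)c1cccc(C(C)C)c1NC(=S)N/N=C/c1ccc2ccccc2n1`: 16400 nM

Of the compounds shown here, three sharing the core of compound 1 have been tested in a functional assay on HeLa cells (Homo sapiens) for antiproliferative activity, read by sulforhodamine B assay, with a stated time of 72 h; on this read-out lower numbers stand for stronger inhibition and higher numbers for weaker inhibition. Compound 1, with its thiocarbonyl group and unsubstituted amide-type nitrogen, gives 960 nM, the lowest of the two numbers recorded in this assay. Compound 3 gives 16400 nM, a much higher number, and the gap between compound 1 and compound 3 lies well beyond the scatter of this assay. Compound 2 is different: its value is a limit of this assay and not a number, (the limit of > 100000 nM in this assay, at which 1 of the 3 values shown sits), so compound 2 cannot be placed on the scale.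

Compound 4, `Fc1ccccc1NC(=S)N/N=C/c1ccc2ccccc2n1`, is not yet measured. It differs from compound 1 in one place: 2-fluorophenyl in place of hydrogen on an amide-type nitrogen. Given that compound 3 gives 16400 nM, the expected step is a 3.1-fold higher number from compound 1 to compound 4 (0.49 log units; beyond the scatter). In this assay compound 4 is therefore estimated at 3000 nM, within a range from 700 nM to 15000 nM.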

Compound 4, half-maximal inhibitory concentration: > 100000 nM
Compound 4: a limit, no number (the forecaster's own chance of this, stated with the estimate: 5%); middle value at least 33-fold (1.52 log units) from the limit.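

In this assay, the value of compound 4 is a limit of the assay and not a number: the limit of > 100000 nM in this assay, at which 2 of the 4 values shown sit. As far as these compounds go, putting 2-fluorophenyl in place of hydrogen on the amide-type nitrogen therefore gives an at least 100-fold higher number from compound 1 to compound 4 (2.01 log units; beyond the scatter), so this one change at this position is enough to take the read-out off the measurable scale, and how far the step really reaches stays unknown. For the compounds shown here, the earlier compounds showed only that a group on this nitrogen can go with a higher number, with compound 3 still giving a measured 16400 nM.

From the compounds shown here alone, what remains open is whether methyl or plain phenyl on this nitrogen would keep a number close to that of compound 1. Also open, going by these compounds, is whether the fluorine itself matters, which phenyl carrying chlorine or methoxy in its place could help to settle.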